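The source may hold more compounds than are shown below. What is called first, only, known or untested is meant among the compounds shown, and "the series" means these compounds.

Measured in a functional assay on B16 cells (Mus musculus) for inhibition; a lower number here means a stronger inhibitor, a higher number a weaker inhibitor:
- compound 1 `CC(C)CN(CC(=O)N(CC(C)C)NC(=O)OCc1ccccc1)/N=C/c1ccccc1B(O)O`: 26300 nM
- compound 2 `CC(C)CN(NC(=O)OCc1ccccc1)C(=O)CN(Cc1ccccc1)/N=C/c1ccccc1B(O)O`: 65500 nM
- compound 3 `CC(C)CN(CC(=O)NN(Cc1ccccc1)c1cnccn1)/N=C/c1cccc(B(O)O)c1`: > 80000 nM (a limit, not a number)

Of the two numeric values in this assay, the higher belongs to compound 2 at 65500 nM, which makes it the weaker inhibitor of the pair. Its nearest neighbour is compound 1, and the gap is a 2.5-fold higher number from compound 1 to compound 2 (0.40 log units; beyond the scatter). For the measured compounds named here, this is a modest step, and it is the only measured step.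

Compound 4 `CC(C)CN(NC(=O)OCc1ccccc1)C(=O)CN(Cc1ccccc1)/N=C/c1ccc(B(O)O)cc1` differs from compound 2 at one place: a group of 9 heavy atoms (6 carbon, 1 boron, 2 oxygen; one six-membered aromatic ring of carbon only) in place of a group of 9 heavy atoms (6 carbon, 1 boron, 2 oxygen; one six-membered aromatic ring of carbon only), on a carbon with a double bond to nitrogen. The two have the same atoms, joined differently. The measured step lies elsewhere, as phenyl in place of isopropyl on a saturated chain carbon bound to an amine nitrogen, so it gives only a rough scale for a single change and no direction for this one. Going by the values given here, no measured step covers the exchange on the carbon with a double bond to nitrogen. No step beyond the scatter is therefore expected in either direction.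

The expected change is a 1.1-fold lower number from compound 2 to compound 4 (0.04 log units; within the scatter). The assay also has (the limit of > 80000 nM in this assay, at which 1 of the 3 values shown sits), from compound 3, so a limit rather than a number is a real possibility here.

The estimate for compound 4 is 60000 nM, with an expected range of 25000 nM to 120000 nM.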

Compound 4, half-maximal inhibitory concentration: 32600 nM
Beside the measured number, compound 4's estimate is 1.8-fold (0.26 log units) above it; low and high end bracket the measured number.
By their numbers in this assay, from the lowest: compounds 1, 4 and 2 (each within the scatter of the next, the first and the last beyond it). At a limit, above all of these: compound 3.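

In this assay, for the compounds shown here, compound 4 gives the first reading of a change on a carbon with a double bond to nitrogen, where one group of 9 heavy atoms takes the place of another with the same atoms joined differently: a 2.0-fold lower number from compound 2 to compound 4 (0.30 log units; within the scatter). Going by these compounds alone, this rearrangement, with the phenyl-bearing side chain of compound 2 kept in place, therefore produces no step that can be told from repeat scatter, while the only earlier step, a 2.5-fold higher number from compound 1 to compound 2 (0.40 log units; beyond the scatter), lies elsewhere, on a saturated chain carbon bound to an amine nitrogen. Nothing on hand gives a cause for this result.

As far as these compounds go, it remains open whether the same rearrangement would read alike with the isopropyl-bearing side chain of compound 1, and what a carboxylic acid would give in place of the boron-bearing group on the aromatic ring. Compound 3 gives > 80000 nM, which is a limit and not a number, and it differs from the other compounds in more than one place, so it offers no comparison for this change.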